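Swapping the alkyne-linked heteroaryl: pyridine to thiazole

This account rests on a few compounds, and the source may have more. Where it says the series, first, only, none or still open, it means among the compounds named here.

Measured compounds:
compound 1, `O=C(O)CCc1ccc(C#Cc2cccs2)cc1`, 251 nM
compound 2, `O=C(O)CCc1ccc(C#Cc2ccc(Cl)nc2)cc1`, 708 nM
compound 3, `O=C(O)CCc1ccc(C#Cc2cccnc2)cc1`, 6030 nM

In an in vitro functional assay on 1321-N1 cells for agonist activity at Free fatty acid receptor 1 (Homo sapiens), read by fluorescence, spectrophotometry and calcium flux (on this read-out higher numbers stand for an effect only at larger amounts of compound and lower numbers for an effect already at smaller amounts), compound 3 gives the highest number of the three; compound 2 is closest, with an 8.5-fold higher number from compound 2 to compound 3 (0.93 log units; beyond the scatter), and compound 1 furthest, with a 24-fold higher number from compound 1 to compound 3 (1.38 log units; beyond the scatter). Compound 4, `O=C(O)CCc1ccc(C#Cc2cncs2)cc1`, differs from compound 3 by 1,3-thiazol-5-yl in place of pyridin-3-yl on a triple-bonded carbon. Among the compounds with values here, the step that bears on this is the one from compound 1 to compound 3, a large change; the new ring shares the five-membered sulfur-containing ring of compound 1 and the ring nitrogen of compound 3. Compound 4 is therefore expected to give a lower number than compound 3, with a step of a 4.0-fold lower number from compound 3 to compound 4 (0.60 log units; beyond the scatter) because a 24-fold higher number from compound 1 to compound 3 (1.38 log units; beyond the scatter) was large. The estimate for compound 4 is 1500 nM, in the range 400 nM to 5000 nM.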

Compound 4, half-maximal effective concentration: 3890 nM
Estimate against measurement, compound 4: 2.6-fold (0.41 log units) below, and the stated range covers the measured number.
By their numbers in this assay, from the lowest: compound 1; then compound 2; then compounds 4 and 3 (each within the scatter of the next).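

Compound 4 cannot be told apart from compound 3, with a 1.6-fold lower number from compound 3 to compound 4 (0.19 log units; within the scatter), so 1,3-thiazol-5-yl on the triple-bonded carbon does not recover the low number seen with thiophen-2-yl. The gap remains large, with a 15-fold higher number from compound 1 to compound 4 (1.19 log units; beyond the scatter), so among these compounds a five-membered aromatic ring with sulfur is not enough to match compound 1. Nothing available explains the difference between these two five-membered rings. Chloro on the pyridine ring mattered, with an 8.5-fold higher number from compound 2 to compound 3 (0.93 log units; beyond the scatter), but its effect on the 1,3-thiazol-5-yl ring remains open. As far as these compounds go, the effect of a methyl group or an amine on that ring is also open.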